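The compounds below may be only part of what the source reports. "The series", "measured", "known", "first", "only" and "open" are said of these compounds alone.

Measured so far:
compound 1, `COc1cccc(OC)c1C(=O)Nc1c[nH]nc1C(=O)NC1CCCCCC1`: 42000 nM
compound 2, `CCc1ccccc1C(=O)Nc1c[nH]nc1C(=O)N[C@H]1CC[C@H](OC)CC1`: 3400 nM

Both were tested in an ADME assay on MRC5 cells (Homo sapiens) for inhibition, with a stated time of 72 h; a higher number here means that more compound is needed for the effect, a lower number that less compound is needed. For the measured compounds named here, of the two numbers, compound 1 stands at the higher one, and the gap to compound 2 lies beyond the usual scatter, so compound 1 is the one that needs more compound for the effect. Going by the values given here, the two compounds differ in more than one place, so no single step between them can be read off. Compound 3, `COc1cccc(OC)c1C(=O)Nc1c[nH]nc1C(=O)Nc1ccccc1`, keeps the rest of compound 1 unchanged and alters one end of it: phenyl in place of cycloheptyl on an amide-type nitrogen. Nothing measured here shows how this change moves the number. A step of modest size, within or only just beyond the scatter and of open direction, is the expectation; the estimated step is a 1.4-fold lower number from compound 1 to compound 3 (0.15 log units; within the scatter). Compound 3 is therefore expected to give 30000 nM, with a likely range from 8000 nM to 120000 nM.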

Compound 3, half-maximal effective concentration: > 50000 nM
Compound 3 was reported as a limit; the forecaster's own chance of this, stated with the estimate: 25%; middle value at least 1.6-fold (0.22 log units) away from the limit.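

On an amide-type nitrogen in this assay, phenyl in place of cycloheptyl gives an at least 1.1-fold higher number from compound 1 to compound 3 (0.07 log units; that floor lies within the scatter). The reading for compound 3 is a limit of the assay and not a number: the limit of > 50000 nM in this assay, at which 1 of the 3 values shown sits. So this swap of a seven-membered non-aromatic ring for a six-membered aromatic one brings no lower number, although the floor of the step alone cannot show a real rise, and the true size of the step stays unknown.

Still open, on these data alone, is whether a longer chain such as hexyl on this nitrogen, or a phenyl ring carrying an amine or a carboxylic acid, would move the number in either direction. Compound 2 differs from compound 1 and compound 3 in more than one place, so it cannot settle what this nitrogen's group contributes.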